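A few compounds are considered here, and "the series" means these few. Any claim that something is new, unique, unknown or untested is made for them only; others in the source may bear on it.

Measured compounds:
compound 1, `S=C=NCCCCSCc1ccccc1`, 20700 nM
compound 2, `CC[S+]([O-])CCCCN=C=S`, 9810 nM

In a functional assay on SH-SY5Y cells (Homo sapiens) for cytotoxicity, read by MTT assay, with a stated time of 72 h (on this read-out lower numbers stand for stronger inhibition and higher numbers for weaker inhibition), compound 1 gives 20700 nM. In this assay compound 2 gives 9810 nM, the lower of the two numbers recorded; the gap between compound 1 and compound 2 lies beyond the usual scatter, so compound 2 is the stronger inhibitor of the two measured.

Compound 3, `CCCC[S+]([O-])CCCCN=C=S`, has not yet been measured. It differs from compound 2 by one change: ethyl in place of hydrogen on a saturated chain carbon, two bonds along the chain from a sulfur. Going by the values given here, no step between measured compounds covers this kind of change, so there is nothing in the data that would fix its size or direction. Compound 3 is therefore expected to stay close to compound 2, with the expected step of a 1.4-fold lower number from compound 2 to compound 3 (0.15 log units; within the scatter) small and probably within the scatter, leaning if anything toward a slightly lower number. The estimate for compound 3 in this assay is 7000 nM, with a range from 3000 nM to 16000 nM.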

Compound 3, half-maximal inhibitory concentration: 6470 nM
The estimate for compound 3 lay 1.1-fold (0.03 log units) above the measured number; the measured number falls inside the stated range.
By their numbers in this assay, from the lowest: compounds 3 and 2 (each within the scatter of the next); then compound 1.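

In this assay, ethyl in place of hydrogen on a saturated chain carbon, two bonds along the chain from a sulfur, gives a 1.5-fold lower number from compound 2 to compound 3 (0.18 log units; within the scatter). Going by these compounds alone, this is the first step measured at this position, and it shows that the position takes the change, which can equally be read as ethyl to butyl, with no shift that stands clear of the scatter. Nothing in the data accounts for the size of this step.

With a single step at this position, the compounds shown leave open whether a longer chain, such as hexyl or octyl, would move the number beyond the scatter. They also leave open whether a chain ending in a hydroxyl group or an amine would behave like the ethyl and butyl chains.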